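The source may report more compounds than this note shows. Statements on the series, on what has been measured and on what is new or still open speak of the compounds shown alone.

Measured compounds:
compound 1, `CN(CCNCc1cn(-c2ccc(Cl)cc2)nn1)CCNc1ccnc2cc(Cl)ccc12`, 9500 nM
compound 2, `CN(CCNCc1cn(-c2ccccc2Cl)nn1)CCNc1ccnc2cc(Cl)ccc12`, 12000 nM
compound 3, `CN(CCNCc1cn(-c2ccc(Br)cc2)nn1)CCNc1ccnc2cc(Cl)ccc12`, 11000 nM

These three numbers come from a functional assay on HCC827 cells (Homo sapiens) for antiproliferative activity, read by sulforhodamine B assay, with a stated time of 72 h; on this read-out higher numbers stand for weaker inhibition and lower numbers for stronger inhibition. Compound 1 gives the lowest of the three, but its nearest neighbour is compound 3 at a 1.2-fold higher number from compound 1 to compound 3 (0.06 log units; within the scatter), and its furthest is compound 2 at a 1.3-fold higher number from compound 1 to compound 2 (0.10 log units; within the scatter), so the three compounds cannot be told apart on this read-out.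

Compound 4, `CN(CCNCc1cn(Cc2nc3cc(Cl)ccc3[nH]2)nn1)CCNc1ccnc2cc(Cl)ccc12`, differs from compound 1 in one place: (5-chloro-1H-benzimidazol-2-yl)methyl in place of 4-chlorophenyl on an aromatic nitrogen. Within the data shown here, no measured step makes this exact change. Among the measured compounds shown here, the steps that bear on the same position are the swaps on the aromatic nitrogen, a 1.3-fold higher number from compound 1 to compound 2 (0.10 log units; within the scatter) and a 1.1-fold lower number from compound 2 to compound 3 (0.04 log units; within the scatter), both within the scatter, and both kept a six-membered carbon ring there; the group entering in compound 4 is larger and brings a donor and an acceptor, which no measured compound tests. The expectation is therefore no step beyond the scatter in this assay, with a wide margin for the untested group: compound 4 is estimated at 10000 nM, between 3500 nM and 30000 nM, a change of a 1.1-fold higher number from compound 1 to compound 4 (0.02 log units; within the scatter).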

Compound 4, half-maximal inhibitory concentration: 65000 nM
Beside the measured number, compound 4's estimate is 6.5-fold (0.81 log units) below it; the whole stated range lies below it.
By their numbers in this assay, from the lowest: compounds 1, 3 and 2 (each within the scatter of the next); then compound 4.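

In this assay, this position on the aromatic nitrogen turns out not to be indifferent to what sits there: the earlier swaps among substituted phenyl groups stayed within the scatter, whereas (5-chloro-1H-benzimidazol-2-yl)methyl gives a 6.8-fold higher number from compound 1 to compound 4 (0.84 log units; beyond the scatter), and likewise a 5.9-fold higher number from compound 3 to compound 4 (0.77 log units; beyond the scatter) and a 5.4-fold higher number from compound 2 to compound 4 (0.73 log units; beyond the scatter). All three steps point towards weaker inhibition, so the change costs activity from each of the three starting compounds. Nothing available here speaks to what lies behind this loss.

Compound 4 brings in a methyl link and a five-membered aromatic ring together, and the compounds shown cannot separate these two parts. A 4-chlorobenzyl group, which keeps the link but has only the carbon ring, would help to tell them apart.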